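This account rests on a few compounds, and the source may have more. Where it says the series, first, only, none or still open, it means among the compounds named here.

In a functional assay on P388D1 cells (Homo sapiens) for antiproliferative activity, read by sulforhodamine B assay, with a stated time of 48 h (on this read-out higher numbers stand for weaker inhibition and lower numbers for stronger inhibition), compound 1 (`CCc1cccc(NS(=O)(=O)c2ccc(N3CCNC3=O)cc2)c1`) gives 250 nM and compound 2 (`Cc1cc(C)cc(NS(=O)(=O)c2ccc(N3CCNC3=O)cc2)c1`) gives 210 nM as its value, which leaves compound 2 level with compound 1 within the scatter. Compound 3 (`Cc1ccc(C)c(NS(=O)(=O)c2ccc(N3CCNC3=O)cc2)c1`) differs from compound 2 in one place, with 2,5-dimethylphenyl in place of 3,5-dimethylphenyl on a sulfonamide nitrogen. Within the data shown here, the only measured step at that place is a 1.2-fold lower number from compound 1 to compound 2 (0.08 log units; within the scatter) and no compound with 2,5-dimethylphenyl has a value yet. In this assay no step beyond the scatter is therefore expected, in either direction. Compound 3 is estimated at 250 nM (expected range 100 nM to 600 nM). Expressed as an estimated step, this reads (a 1.2-fold higher number from compound 2 to compound 3 (0.08 log units; within the scatter)).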

Compound 3, half-maximal inhibitory concentration: 79 nM
For compound 3 the middle estimate is 3.2-fold (0.50 log units) above the measured one, outside the stated range (below it).
By their numbers in this assay, from the lowest: compound 3; then compounds 2 and 1 (each within the scatter of the next).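

In this assay the result shows that this place on the sulfonamide nitrogen responds to how the same atoms are arranged: 2,5-dimethylphenyl in place of 3,5-dimethylphenyl gives a 2.7-fold lower number from compound 2 to compound 3 (0.42 log units; beyond the scatter), a step beyond the scatter, which the earlier change here did not reach. The 2,5-dimethylphenyl group also separates from 3-ethylphenyl, with a 3.2-fold lower number from compound 1 to compound 3 (0.50 log units; beyond the scatter) as the step. Nothing available explains these steps. The compounds shown leave open whether a methoxy group or a chlorine on this ring would keep the lower number, and whether an unsubstituted phenyl would lose it.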